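Swapping the Bromo Ring for a Trifluoromethyl Ring

The compounds below may be only part of what the source reports. "The series", "measured", "known", "first", "only" and "open" are said of these compounds alone.

Measured compounds:
- compound 1, `CN(C)C(=O)c1cc2cnc(Nc3ccc(NC(=O)C4(C(=O)Nc5ccccc5)CC4)cc3)nc2n1C1CCCC1`: 75%
- compound 2, `CN(C)C(=O)c1cc2cnc(Nc3ccc(NC(=O)C4(C(=O)Nc5ccccc5F)CC4)cc3)nc2n1C1CCCC1`: 79.1%
- compound 3, `CN(C)C(=O)c1cc2cnc(Nc3ccc(NC(=O)C4(C(=O)Nc5ccc(Br)cc5)CC4)cc3)nc2n1C1CCCC1`: -6.6%

All three share one core and differ only in the ring on the amide-type nitrogen. In a functional assay on A549 cells (Homo sapiens) for inhibition, read by CCK-8 assay, with a stated time of 72 h, tested at 1 uM (on this read-out lower numbers stand for less inhibition of growth and higher numbers for more inhibition of growth at the one concentration tested), compound 3 stands lowest of the three; its nearest neighbour is compound 1, and compound 2 lies furthest from it. The step to compound 4, `CN(C)C(=O)c1cc2cnc(Nc3ccc(NC(=O)C4(C(=O)Nc5cccc(C(F)(F)F)c5)CC4)cc3)nc2n1C1CCCC1`, changes that ring once more: 3-(trifluoromethyl)phenyl in place of 4-bromophenyl on an amide-type nitrogen.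

Within the data shown here, no measured step carries a trifluoromethyl group, so the closest guides are the two steps that end at compound 3: a number 81.6 percentage points lower from compound 1 to compound 3 (beyond the scatter) and a number 85.7 percentage points lower from compound 2 to compound 3 (beyond the scatter). Both show that putting a bromine on the ring wiped out nearly all growth inhibition, whereas a number 4.1 percentage points higher from compound 1 to compound 2 (within the scatter) shows that a fluorine left the number essentially unchanged. The new group is neither of these, so the direction is uncertain; the most that can be said is that compound 3 sits at the floor, leaving more room upward than downward.

For compound 4 the expected value in this assay is 35%, with a likely range from -10% to 75%. That estimate amounts to a step of a number 41.6 percentage points higher from compound 3 to compound 4 (beyond the scatter), but it rests on little and should be held loosely.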

Compound 4, percent growth inhibition at one concentration: 15.7%
Estimate against measurement, compound 4: 19.3 percentage points above; the measured number falls inside the stated range.
By their numbers in this assay, from the lowest: compound 3; then compound 4; then compounds 1 and 2 (each within the scatter of the next).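

In this assay, the change to 3-(trifluoromethyl)phenyl gives back only part of what the 4-bromophenyl ring lost, with a number 22.3 percentage points higher from compound 3 to compound 4 (beyond the scatter), while the result still falls short of the two rings that keep the number high: a number 63.4 percentage points lower from compound 2 to compound 4 (beyond the scatter) and a number 59.3 percentage points lower from compound 1 to compound 4 (beyond the scatter). Among these compounds, this shows that the ring on the amide-type nitrogen does not simply switch growth inhibition on or off, since an intermediate level is possible, and that bromine is not the only added group that lowers the number, although the fluorine of compound 2 goes against any rule that every added group does so. The data shown offer no measured explanation for why these rings differ.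

Because 4-bromophenyl and 3-(trifluoromethyl)phenyl differ both in the group and in where it sits on the ring, these compounds cannot separate the effect of one from the other. Going by these compounds, it also remains open whether a ring carrying a methoxy group, an amine or a carboxylic acid would stay near compound 1 or fall towards compound 3.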